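Swapping the Sulfonamide Ring: Expected Clearance of Compound 4

The source may report more compounds than this note shows. Statements on the series, on what has been measured and on what is new or still open speak of the compounds shown alone.

Of the compounds shown here, three sharing one core have been measured in an ADME assay on microsomes (Mus musculus) for metabolic stability; on this read-out lower numbers stand for slow clearance and higher numbers for fast clearance. Compound 1 `CNC(=O)[C@@H]1CCCN1S(=O)(=O)c1ccc(Cl)c(COc2cccc3c(C(F)(F)F)cc(C)nc23)c1Cl` gives 1380 mL/min/kg. Compound 2 `Cc1cc(C(F)(F)F)c2cccc(OCc3c(Cl)ccc(S(=O)(=O)N4CCC[C@H]4CO)c3Cl)c2n1` gives 1630 mL/min/kg, and compound 3 `Cc1cc(C(F)(F)F)c2cccc(OCc3c(Cl)ccc(S(=O)(=O)N4CCCCC4)c3Cl)c2n1` gives 1000 mL/min/kg. Compound 1 therefore sits among three numbers that all lie within the scatter of one another: the nearest neighbour is a 1.2-fold higher number from compound 1 to compound 2 (0.07 log units; within the scatter), the furthest is a 1.4-fold lower number from compound 1 to compound 3 (0.14 log units; within the scatter).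

Compound 4 `Cc1cc(C(F)(F)F)c2cccc(OCc3c(Cl)ccc(S(=O)(=O)N4CCC(C#N)CC4)c3Cl)c2n1` has not yet been measured in this assay. It differs from compound 1 in one place: 4-cyanopiperidin-1-yl in place of 2-(methylcarbamoyl)pyrrolidin-1-yl on a sulfonyl sulfur. Within the data shown here, two measured steps bear on this change, since both also replace a substituted pyrrolidinyl ring on the sulfonyl sulfur with a piperidinyl ring: a 1.4-fold lower number from compound 1 to compound 3 (0.14 log units; within the scatter) and a 1.6-fold lower number from compound 2 to compound 3 (0.21 log units; within the scatter). Both stayed within the scatter, and the closest measured relative of compound 4 is compound 3, which shares the six-membered ring and gives 1000 mL/min/kg, pointing to a number in the same region. No step beyond the scatter is expected in either direction.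

The expected value for compound 4 in this assay is estimated at 1100 mL/min/kg, with a range from 550 mL/min/kg to 2200 mL/min/kg. This expectation amounts to a 1.3-fold lower number from compound 1 to compound 4 (0.10 log units; within the scatter).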

Compound 4, clearance: 1720 mL/min/kg
Beside the measured number, compound 4's estimate is 1.6-fold (0.19 log units) below it; low and high end bracket the measured number.
By their numbers in this assay, from the lowest: compounds 3, 1, 2 and 4 (each within the scatter of the next).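

Among these compounds, the cleanest reading comes from the piperidine ring itself: in this assay, cyano in place of hydrogen on a saturated ring carbon gives the step from the unsubstituted ring (a 1.7-fold higher number from compound 3 to compound 4 (0.24 log units; within the scatter)), so a substituent on this ring can be read directly for the first time, and this one stays within the scatter. Exchanging a substituted five-membered ring for 4-cyanopiperidin-1-yl on the sulfonyl sulfur also stays within the scatter, both for the methylcarbamoyl compound (a 1.2-fold higher number from compound 1 to compound 4 (0.10 log units; within the scatter)) and for the hydroxymethyl compound (a 1.1-fold higher number from compound 2 to compound 4 (0.02 log units; within the scatter)), so a change of ring size, substituent and stereocentre together shows no clear effect on this read-out. No measurement at hand offers a cause for any of these steps.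

Still open, going by these compounds, is whether another group on the piperidine ring, such as a carboxylic acid, a primary amine or a longer alkyl chain, would move the number beyond the scatter. Also open, on these data alone, is whether a morpholine ring or an open-chain amine on the sulfonyl sulfur would do so, or whether this position matters at all for clearance on the shared core.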